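The source may hold more compounds than are shown below. What is called first, only, known or untested is meant among the compounds shown, and "the series" means these compounds.

The measured compounds:
compound 1, `CC1=CC[C@H](C(C)C)c2cc(C)c(OC(=O)Nc3ccccc3)cc21`, gives 100% in a functional assay on U-251 cells (Homo sapiens) for antiproliferative activity, read by sulforhodamine B assay, with a stated time of 48 h, tested at 50 uM; a higher number here means more inhibition at the concentration tested (going by the name of the read-out), a lower number less inhibition
compound 2, `CC1=CC[C@H](C(C)C)c2cc(C)c(OC(=O)c3ccccc3)cc21`, gives 25.8%
compound 3, `CC1=CC[C@H](C(C)C)c2cc(C)c(OC(=O)c3cccc(Cl)c3)cc21`, gives 0.9%

Compound 3 stands lowest of the three numbers in this assay. Its nearest neighbour is compound 2, a modest distance away: a number 24.9 percentage points lower from compound 2 to compound 3 (beyond the scatter). Compound 1 lies furthest off: a number 99.1 percentage points lower from compound 1 to compound 3 (beyond the scatter).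

Compound 4, `CC1=CC[C@H](C(C)C)c2cc(C)c(OC(=O)c3cccc(C)c3)cc21`, has not yet been measured. It differs from compound 3 in one place: methyl in place of chloro on an aromatic carbon. Within the data shown here, no measured step exchanges methyl for chloro anywhere in this set. Among the measured compounds shown here, the only step that touches the same aromatic carbon is the one in which chloro entered in place of hydrogen: a number 24.9 percentage points lower from compound 2 to compound 3 (beyond the scatter), a modest downward move. The two remaining steps, a number 74.2 percentage points lower from compound 1 to compound 2 (beyond the scatter) and a number 99.1 percentage points lower from compound 1 to compound 3 (beyond the scatter), concern the carbonyl carbon and were large, but they do not bear on a change within the phenyl ring.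

Methyl is neither hydrogen nor chloro, and the data give no direct guide for it. The author therefore expects compound 4 to land between compound 3 and compound 2, and nearer compound 3, so that the step is estimated as a number 11.1 percentage points higher from compound 3 to compound 4 (beyond the scatter): a small rise at most, possibly none beyond the scatter. Compound 4 is expected to give about 12%, within a range of 0% to 35%.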

Compound 4, a percentage reported as inhibition, at one concentration (the size of the read-out at that concentration, not a potency): 16.8%
For compound 4 the middle estimate is 4.8 percentage points below the measured one; the range from low to high includes it.
By their numbers in this assay, from the lowest: compound 3; then compounds 4 and 2 (each within the scatter of the next); then compound 1.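

In this assay, exchanging chloro for methyl on this aromatic carbon, meta to a large group, gives a measurable change (step: a number 15.9 percentage points higher from compound 3 to compound 4 (beyond the scatter)), so the two single-atom replacements of hydrogen at this position do not behave alike, even though each adds one heavy atom. Chloro in place of hydrogen had moved the number beyond the scatter (step: a number 24.9 percentage points lower from compound 2 to compound 3 (beyond the scatter)), whereas methyl in place of hydrogen does not (step: a number 9 percentage points lower from compound 2 to compound 4 (within the scatter)), so compound 2 and compound 4 cannot be told apart here and the fall seen with chloro does not extend to methyl. Against these ring changes, the exchange at the carbonyl carbon remains much the larger (step: a number 83.2 percentage points lower from compound 1 to compound 4 (beyond the scatter)), so the anilino group still sets the main difference within this set.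

The data offer no explanation for the difference between chloro and methyl at this position. As far as these compounds go, whether a methoxy group, an amine or a carboxylic acid on the same carbon would resemble chloro or methyl remains open, as does whether the gap between chloro and methyl would persist on an anilino carbonyl such as that of compound 1.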